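Shrinking the Amide on the Carbonyl Carbon

This account rests on a few compounds, and the source may have more. Where it says the series, first, only, none or still open, it means among the compounds named here.

Compound 2 `CCN1CCN(C(=O)c2cccn2-c2ccc(Nc3ncc(Cl)c(Nc4ccccc4NS(C)(=O)=O)n3)c(OC)c2)CC1` returns, in a functional assay on A549 cells (Homo sapiens) for antiproliferative activity, read by MTT assay, with a stated time of 72 h (on this read-out higher numbers stand for weaker inhibition and lower numbers for stronger inhibition), only a limit of > 10000 nM. The methyl ester compound 1 `COC(=O)c1cccn1-c1ccc(Nc2ncc(Cl)c(Nc3ccccc3NS(C)(=O)=O)n2)c(OC)c1` gives 2510 nM in this assay. Compound 3 `COc1cc(-n2cccc2C(=O)NCCO)ccc1Nc1ncc(Cl)c(Nc2ccccc2NS(C)(=O)=O)n1` likewise returns only a limit of > 10000 nM in this assay. The change to compound 4 `COc1cc(-n2cccc2C(=O)N(C)C)ccc1Nc1ncc(Cl)c(Nc2ccccc2NS(C)(=O)=O)n1` is dimethylamino in place of 4-ethylpiperazin-1-yl on a carbonyl carbon. Two measured steps at this carbonyl carbon bear on it: an at least 3.9-fold higher number from compound 1 to compound 2 (0.60 log units; beyond the scatter) and an at least 3.9-fold higher number from compound 1 to compound 3 (0.60 log units; beyond the scatter), both toward weaker inhibition, while a step that the two limits leave unreadable from compound 2 to compound 3 stays unreadable because of the limit of > 10000 nM in this assay, at which 2 of the 3 values shown sit. The measured compounds give no direct reading for a smaller amide, so the expectation for compound 4 is wide and leans on compound 1 and its 2510 nM as the better end. Compound 4 is expected near 5000 nM, between 1500 nM and 20000 nM. This amounts to an expected at least 2.0-fold lower number from compound 2 to compound 4 (0.30 log units; that floor lies within the scatter).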

Compound 4, half-maximal inhibitory concentration: > 10000 nM
Compound 4 was reported as a limit (the forecaster's own chance of this, stated with the estimate: 35%); at least 2.0-fold (0.30 log units) between middle value and limit.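

With dimethylamino on the carbonyl carbon, a group with no ring, this assay still shows an at least 3.9-fold higher number from compound 1 to compound 4 (0.60 log units; beyond the scatter). Compound 4 gives > 10000 nM, which is a limit and not a number. Among the compounds shown, only the methyl ester compound 1 has a measured number, and the steps among compound 2, compound 3 and compound 4 cannot be read because all three rest on the same ceiling: the limit of > 10000 nM in this assay, at which 3 of the 4 values shown sit.

Going by these compounds, how these three amides rank remains open. So does whether a carboxylic acid, an ethyl ester or an unsubstituted amide on this carbonyl carbon would give a measurable number.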